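The source may report more compounds than this note shows. Statements on the series, on what has been measured and on what is new or still open speak of the compounds shown alone.

Measured compounds:
compound 1 `C#CCNC(=O)/C(C)=C(\C)c1cc(OC)c(OC)c(OC)c1` — 150 mg/kg
compound 2 `C/C(C(=O)NC1CC1)=C(/C)c1ccc(Cl)cc1` — 150 mg/kg

Of the compounds shown here, two have been tested in a toxicity assay on the whole organism (strain Icem-CET (SPF Caw)) for cytotoxicity, with Mus musculus as the target; a lower number here means that less compound is needed, a higher number that more compound is needed for the effect. Compound 2 gives 150 mg/kg, and compound 1 gives 150 mg/kg; the two values are level at the digits shown, within the scatter of this assay, so nothing separates them in this assay. The compounds share the same unsaturated amide arrangement and differ in the ring substitution and in the amide substituent, yet the dose for half-maximal effect is the same for both.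

Compound 3 `C/C(C(=O)NC1CC1)=C(/C)c1ccccc1` has not yet been measured. It differs from compound 2 in one place: hydrogen in place of chloro on an aromatic carbon. Going by the values given here, no pair of measured compounds shows this kind of change, so the expectation rests on compound 2 alone. For compound 3 the step of no change at the digits printed from compound 2 to compound 3 (within the scatter) is expected to be no larger than the scatter, in no particular direction. Compound 3 is therefore estimated to give 150 mg/kg in this assay, with a range from 80 mg/kg to 280 mg/kg.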

Compound 3, dose for half-maximal effect: 150 mg/kg
Beside the measured number, compound 3's estimate shows no gap at the digits printed, and the stated range covers the measured number.
By their numbers in this assay, from the lowest: compounds 1, 2 and 3 (each within the scatter of the next).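

In this assay, going by these compounds alone, the replacement of chloro by hydrogen on an aromatic carbon, para to a large group, gives no change at the digits printed from compound 2 to compound 3 (within the scatter) and is the first single-place step that can be read. For this pair, the chlorine atom on the six-membered aromatic ring of carbon only is therefore not required for the dose for half-maximal effect to stay at the level seen with compound 2. No measurement here offers an explanation for this result.

On these data alone, it remains open whether another group in this place, such as an amine or a carboxylic acid, would also stay level with compound 2 in this assay. The compounds shown also leave open whether a longer chain on the amide would alter the dose, and whether the same replacement would read alike on another amide.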